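Urea to amide at the carbonyl of compound 3

A few compounds are considered here, and "the series" means these few. Any claim that something is new, unique, unknown or untested is made for them only; others in the source may bear on it.

Compound 3 `COc1cc(Cl)cc(-c2nn(-c3cccc(NC(=O)Nc4cccc(C(F)(F)F)c4)c3)cc2-c2ccncc2)c1` gives 1030 nM in a functional assay on UO-31 cells (Homo sapiens) for inhibition, read by sulforhodamine B assay, with a stated time of 48 h (on this read-out lower numbers stand for stronger inhibition and higher numbers for weaker inhibition), the lowest of the three numbers, though its distance to compound 1 `COc1cc(Cl)cc(-c2nn(-c3cccc(NC(=O)Nc4ccc(Cl)c(C(F)(F)F)c4)c3)cc2-c2ccncc2)c1` at 1660 nM and to compound 2 `COc1cc(Cl)cc(-c2nn(-c3cccc(NC(=O)Nc4ccc(Cl)c(Cl)c4)c3)cc2-c2ccncc2)c1` at 1890 nM stays within the scatter. Compound 4 `COc1cc(Cl)cc(-c2nn(-c3cccc(NC(=O)c4cccc(C(F)(F)F)c4)c3)cc2-c2ccncc2)c1` differs from compound 3 by 3-(trifluoromethyl)phenyl in place of (3-(trifluoromethyl)phenyl)amino on a carbonyl carbon. Among the measured compounds shown here, no measured step touches the carbonyl-linked unit: the steps of a 1.6-fold lower number from compound 1 to compound 3 (0.21 log units; within the scatter) and a 1.8-fold lower number from compound 2 to compound 3 (0.26 log units; within the scatter) concern only substituents on the distal ring, and a 1.1-fold higher number from compound 1 to compound 2 (0.06 log units; within the scatter) likewise. The data therefore offer no guide to the direction of this change, and the expected step of a 1.7-fold higher number from compound 3 to compound 4 (0.24 log units; within the scatter) in this assay is set near zero with a wide uncertainty. Compound 4 is expected to give about 1800 nM in this assay, in a range from 500 nM to 7000 nM.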

Compound 4, half-maximal inhibitory concentration: 2710 nM
Estimate against measurement, compound 4: 1.5-fold (0.18 log units) below; low and high end bracket the measured number.
By their numbers in this assay, from the lowest: compounds 3, 1, 2 and 4 (each within the scatter of the next, the first and the last beyond it).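

In this assay, among the compounds shown here, replacing (3-(trifluoromethyl)phenyl)amino with 3-(trifluoromethyl)phenyl on the carbonyl carbon gives the first step in this set beyond the scatter, a 2.6-fold higher number from compound 3 to compound 4 (0.42 log units; beyond the scatter). The other two new steps, a 1.4-fold higher number from compound 2 to compound 4 (0.16 log units; within the scatter) and a 1.6-fold higher number from compound 1 to compound 4 (0.21 log units; within the scatter), stay within it, so the change at this position is clear only against compound 3. Nothing available accounts for the step. As far as these compounds go, it remains open whether a longer chain or a piperazine in place of the amino unit on the carbonyl carbon would keep the number of compound 3.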